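Methyl added to a triple-bonded carbon: a single-change forecast

The compounds below may be only part of what the source reports. "The series", "measured", "known", "first", "only" and "open" are said of these compounds alone.

Measured so far:
Compound 1, `CCCCn1c(Cc2cc(OC)c(OC)c(OC)c2)nc2c(N)nc(F)nc21`: 185000000 nM
Compound 2, `CC[C@H](C)Cn1c(Cc2cc(OC)c(OC)c(OC)c2)nc2c(N)nc(F)nc21`: 66700000 nM
Compound 3, `C#CCCn1c(Cc2cc(OC)c(OC)c(OC)c2)nc2c(N)nc(F)nc21`: 286000000 nM

These values come from a functional assay on MCF7 cells (Homo sapiens) for cytotoxicity; a higher number here means that more compound is needed for the effect, a lower number that less compound is needed. Within the data shown here, the step of a 2.8-fold lower number from compound 1 to compound 2 (0.44 log units; beyond the scatter) is the one measured example of a methyl entering. Between compound 1 and compound 3 the cores differ by ethynyl in place of ethyl on a saturated chain carbon, two bonds along the chain from an aromatic nitrogen, and the step of a 1.5-fold higher number from compound 1 to compound 3 (0.19 log units; within the scatter) is small. Compound 3 has the highest number of the three, with a 4.3-fold higher number from compound 2 to compound 3 (0.63 log units; beyond the scatter) the larger gap.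

Compound 4, `CC#CCCn1c(Cc2cc(OC)c(OC)c(OC)c2)nc2c(N)nc(F)nc21`, is not yet measured. It differs from compound 3 by methyl in place of hydrogen on a triple-bonded carbon. Compound 2 differs from compound 1 by methyl in place of hydrogen on a saturated chain carbon bound to two saturated chain carbons. Both add a methyl, but the place is not the same: in compound 2 it sits on a saturated chain carbon bound to two saturated chain carbons, in compound 4 on a triple-bonded carbon whose other neighbour is a triple-bonded carbon, so this is the same kind of change rather than the same change. A step like a 1.9-fold lower number from compound 3 to compound 4 (0.28 log units; within the scatter) is expected for compound 4, resting on the step of a 2.8-fold lower number from compound 1 to compound 2 (0.44 log units; beyond the scatter) seen for compound 2. The place differs, and the expectation is held loosely. The estimate for compound 4 is 150000000 nM, between 60000000 nM and 400000000 nM.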

Compound 4, half-maximal effective concentration: 95500000 nM
The estimate for compound 4 lay 1.6-fold (0.20 log units) above the measured number; low and high end bracket the measured number.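

The methyl step carried over from one core to the other in this assay, with no difference in size that stands out from the scatter: the same change on two cores in this assay, a 2.8-fold lower number (0.44 log units; beyond the scatter) from compound 1 to compound 2 and a 3.0-fold lower number (0.48 log units; beyond the scatter) from compound 3 to compound 4, 1.1-fold (0.03 log units) apart, within the scatter of two such steps. The new step is a 3.0-fold lower number from compound 3 to compound 4 (0.48 log units; beyond the scatter), while the comparisons with the saturated chains, a 1.4-fold higher number from compound 2 to compound 4 (0.16 log units; within the scatter) and a 1.9-fold lower number from compound 1 to compound 4 (0.29 log units; within the scatter), stay within the scatter. Among these compounds, this rests on only two pairs in one cell assay, with the methyl on a different kind of carbon in each, so it shows that the two steps matched here, but not that a methyl would give the same step on other cores or in other places, and it gives no reason for the step.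

The compounds shown leave open how a longer chain, an amine or a carboxylic acid in place of the methyl would read in this assay. They also leave open whether the methyl step would hold if a chlorine replaced the fluorine on the shared core.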